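The compounds below may be only part of what the source reports. "The series", "measured", "known", "first", "only" and "open" are said of these compounds alone.

Measured in an ADME assay on L929 cells (Mus musculus) for cytotoxicity, read by resazurin assay, with a stated time of 72 h; a lower number here means a stronger inhibitor, a higher number a weaker inhibitor:
compound 1 `COCOc1cccc(C(=O)/C=C/c2ccc3c(c2)B(O)OC3)c1`: > 10 ug/mL
compound 2 `COc1cc(C(=O)/C=C/c2ccc3c(c2)B(O)OC3)cc(OC)c1OC`: > 10 ug/mL
compound 3 `O=C(/C=C/c1ccc2c(c1)B(O)OC2)c1ccc(C(F)(F)F)cc1`: > 10 ug/mL

Each entry is a limit of the assay and not a number. Among the measured compounds shown here, compound 3 has only > 10 ug/mL as a limit, and the series so far shows the limit of > 10 ug/mL in this assay, at which 3 of the 3 values shown sit, and no numeric reading.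

Compound 4 `O=C(/C=C/c1ccc2c(c1)B(O)OC2)c1ccc(F)cc1` carries fluoro in place of trifluoromethyl on an aromatic carbon, para to a large group, counted as fluoro in place of trifluoromethyl on an aromatic carbon on an otherwise shared core. No measured step sizes this change. In this assay no change beyond the scatter is expected, and no direction is predicted. The expected step is a step that the limit leaves unreadable from compound 3 to compound 4 as an estimate. For compound 4 the estimate is 15 ug/mL with 7 ug/mL to 40 ug/mL as the expected range.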

Compound 4, half-maximal inhibitory concentration: > 10 ug/mL
Compound 4: a limit, no number; the forecaster's own chance of this, stated with the estimate: 75%; the middle value is on the limit's open side.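

Compound 3 and compound 4 both stand as limits of the assay, and the step between them cannot be read. What stays open is the numeric value of any compound shown in this assay, and whether fluoro in place of trifluoromethyl changes it.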